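Permeability of a furan-linked diamine series: a ring-bearing ether variant

The compounds below may be only part of what the source reports. "The series", "measured", "known", "first", "only" and "open" are said of these compounds alone.

Measured so far:
compound 1 `CC(C)CCc1ccc2c(NCCCNCc3ccco3)ccnc2c1`, 23 10^-6 cm/s
compound 2 `FC(F)(F)c1cccc(Cc2ccc3c(NCCCNCc4ccco4)ccnc3c2)c1`, 23 10^-6 cm/s

In an ADME assay for permeability, using PAMPA, with a stated time of 30 min, at pH 7.4 (on this read-out higher numbers stand for higher permeability and lower numbers for lower permeability), compound 1 gives 23 10^-6 cm/s, and on that number compound 1 stands level with compound 2, which gives 23 10^-6 cm/s. Going by the values given here, the single measured step, no change at the digits printed from compound 1 to compound 2 (within the scatter), shows that an aryl group taking the place of the isobutyl chain left this assay untouched. Compound 3 `CN(C)c1cccc(Oc2ccc3c(NCCCNCc4ccco4)ccnc3c2)c1` is not yet measured. It differs from compound 1 in one place: 3-(dimethylamino)phenoxy in place of isopentyl on an aromatic carbon. Among the compounds with values here, this change also introduces an aromatic ring onto the shared core, here through an oxygen rather than a chain carbon, so the step from compound 1 to compound 2 is the only guide, and it was flat. Compound 3 is therefore expected to sit near compound 1, with the step of a 1.3-fold lower number from compound 1 to compound 3 (0.11 log units; within the scatter) expected to stay within the scatter or fall only slightly. The estimate for compound 3 is 18 10^-6 cm/s, in the range 8 10^-6 cm/s to 35 10^-6 cm/s.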

Compound 3, apparent permeability: 317 10^-6 cm/s
Beside the measured number, compound 3's estimate is 18-fold (1.25 log units) below it; the measured number lies above the stated range.
By their numbers in this assay, from the lowest: compounds 1 and 2 (each within the scatter of the next); then compound 3.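

With 3-(dimethylamino)phenoxy in place of isopentyl on this aromatic carbon, this assay shows a 14-fold higher number from compound 1 to compound 3 (1.14 log units; beyond the scatter), whereas the earlier change to an aryl group gave no change at the digits printed from compound 1 to compound 2 (within the scatter). This position is therefore not indifferent to what it carries, and an aromatic ring alone does not settle the read-out, since compound 2 and compound 3 both bear one. No available evidence bears on what lies behind this large step.

The compounds shown leave open whether the step belongs to the ether oxygen, the dimethylamino group or the two together. An unsubstituted phenoxy group and a 3-(dimethylamino)benzyl group on the same aromatic carbon would separate these, and a methoxy or morpholine group in place of the dimethylamino group would test how specific that amine is.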